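Exchanging the 2-hydroxyphenyl ester of compound 1 for pyridin-4-yl

A few compounds are considered here, and "the series" means these few. Any claim that something is new, unique, unknown or untested is made for them only; others in the source may bear on it.

Working notes on the series. Within the data shown here, in an ADME assay on a cell-free system (plasma, Homo sapiens) for metabolic stability, with Plasma (Rattus norvegicus) as the target, read by HPLC, at pH 7.4 (a lower number here means that the compound disappears faster, a higher number that the compound lasts longer), compound 1 `CC(=O)Oc1ccccc1C(=O)O[C@H]1CO[C@H]2[C@@H]1OC[C@H]2OC(=O)c1ccccc1O` gives 0.019 h, the second highest of the three numbers measured so far. Compound 2 `CC(=O)Oc1ccccc1C(=O)O[C@H]1CO[C@H]2[C@@H]1OC[C@H]2OC(C)=O` gives 0.0095 h, a step of a 2.0-fold lower number from compound 1 to compound 2 (0.30 log units; within the scatter), and compound 3 `CC(=O)Nc1cccc(C(=O)O[C@@H]2CO[C@H]3[C@@H]2OC[C@@H]3OC(=O)c2ccccc2OC(C)=O)c1` gives 0.0583 h, a step of a 3.1-fold higher number from compound 1 to compound 3 (0.49 log units; beyond the scatter). Compound 4 `CC(=O)Oc1ccccc1C(=O)O[C@H]1CO[C@H]2[C@@H]1OC[C@H]2OC(=O)c1ccncc1` differs from compound 1 by pyridin-4-yl in place of 2-hydroxyphenyl on a carbonyl carbon. Both measured exchanges at this carbonyl carbon bear on it: the methyl exchange stayed within the scatter, whereas the 3-acetamidophenyl exchange ran modestly higher, so this position has so far moved this assay by no more than a modest step. For compound 4 a similarly modest shift, most likely little beyond the scatter, is expected. Compound 4 is estimated at 0.03 h, in a range from 0.012 h to 0.08 h, meaning an expected step of a 1.6-fold higher number from compound 1 to compound 4 (0.20 log units; within the scatter).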

Compound 4, half-life: 0.0055 h
Beside the measured number, compound 4's estimate is 5.5-fold (0.74 log units) above it; measured number below the stated range.
By their numbers in this assay, from the lowest: compounds 4, 2 and 1 (each within the scatter of the next, the first and the last beyond it); then compound 3.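

In this assay this carbonyl position can also lower the number beyond the scatter, with pyridin-4-yl giving a 3.5-fold lower number from compound 1 to compound 4 (0.54 log units; beyond the scatter) and, against the other exchange, an 11-fold lower number from compound 3 to compound 4 (1.03 log units; beyond the scatter). The remaining step, a 1.7-fold lower number from compound 2 to compound 4 (0.24 log units; within the scatter), shows that an aromatic ring here does not by itself raise the number over methyl, although compound 3 shows that a ring can carry a higher one. Nothing available explains these steps. Still open, going by these compounds, is whether a phenyl ring carrying an amine or a carboxylic acid would fall with compound 4 or with compound 3.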